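Swapping the side chain of compound 1

The compounds below may be only part of what the source reports. "The series", "measured", "known", "first", "only" and "open" are said of these compounds alone.

Measured in a functional assay on SH-SY5Y cells (Homo sapiens) for cytotoxicity, read by MTT assay, with a stated time of 72 h; a higher number here means a weaker inhibitor, a lower number a stronger inhibitor:
- compound 1 `O=C1c2c[n+]([O-])c3ccccc3c2C(=O)c2c1c1ccccc1n2Cc1cn(CC(O)CO)nn1`: > 1000 nM
- compound 2 `CC1(C)O[C@@H](CO)[C@H](Cn2cc(Cn3c4c(c5ccccc53)C(=O)c3c[n+]([O-])c5ccccc5c3C4=O)nn2)O1`: > 1000 nM

Compound 1 has only a limit, > 1000 nM, and no exact number. Compound 2 likewise has only a limit, > 1000 nM. The measured evidence therefore amounts to the limit of > 1000 nM in this assay, at which 2 of the 2 values shown sit. Going by the values given here, the single measured step, a step that the two limits leave unreadable from compound 1 to compound 2, has no readable size and leaves little to carry over.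

Compound 3 `O=C1c2c[n+]([O-])c3ccccc3c2C(=O)c2c1c1ccccc1n2CCN1CCCCC1` awaits measurement in this assay. It differs from compound 1 by (piperidin-1-yl)methyl in place of 1-(2,3-dihydroxypropyl)-1H-1,2,3-triazol-4-yl on a saturated chain carbon bound to an aromatic nitrogen, with (piperidin-1-yl)methyl in place of 1-(2,3-dihydroxypropyl)-1H-1,2,3-triazol-4-yl on a saturated chain carbon bound to an aromatic nitrogen.

Among the compounds with values here, no measured step fixes a size or direction for this change, so only a loose expectation is possible, and a further limit would be no surprise. The estimated step is a step that the limit leaves unreadable from compound 1 to compound 3. For compound 3 the expected value is 1500 nM, with an estimated range from 300 nM to 8000 nM.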

Compound 3, half-maximal inhibitory concentration: 1860 nM
The estimate for compound 3 lay 1.2-fold (0.09 log units) below the measured number, within the range that was stated.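

No new step can be read here: compound 3 has an exact number, but compound 1 has only a limit, and compound 2 likewise. The compounds shown leave open how the 2-(piperidin-1-yl)ethyl chain of compound 3 compares with any side chain measured exactly.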